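Aryl Sulfone Replacement in a Prostaglandin D2 Receptor 2 Series

A few compounds are considered here, and "the series" means these few. Any claim that something is new, unique, unknown or untested is made for them only; others in the source may bear on it.

Measured compounds:
- Compound 1, `COc1cccc(S(=O)(=O)c2ccccc2Cc2c3c(n(CC(=O)O)c2C)CCNC3=O)c1`: in a functional assay on CHO.K1 cells for antagonist activity at prostaglandin D2 receptor 2 (Homo sapiens), read by GTPgammaS binding, with a stated time of 1 h (on this read-out higher numbers stand for weaker inhibition and lower numbers for stronger inhibition), compound 1 gives 12 nM.
- Compound 2, `CNC(=O)c1cccc(S(=O)(=O)c2ccccc2Cc2c3c(n(CC(=O)O)c2C)CCNC3=O)c1`: in this assay compound 2 gives 240 nM.

Compound 2 has the higher of the two numbers. Its nearest neighbour is compound 1, and the step of a 20-fold higher number from compound 1 to compound 2 (1.30 log units; beyond the scatter) is large and beyond the scatter. Compound 3, `Cc1c(Cc2ccccc2S(=O)(=O)c2ccc(OC(F)(F)F)cc2)c2c(n1CC(=O)O)CCNC2=O`, has not yet been measured; it differs from compound 2 in one place: 4-(trifluoromethoxy)phenyl in place of 3-(methylcarbamoyl)phenyl on a sulfonyl sulfur. Within the data shown here, the only measured step that bears on this change is the one from compound 1 to compound 2, which altered the same aryl group on the sulfonyl sulfur and moved the number a long way. Since compound 3 again changes that aryl group, and since compound 1 gives 12 nM with a methoxy group there, the account expects compound 3 to move back toward compound 1, a step estimated as a 12-fold lower number from compound 2 to compound 3 (1.08 log units; beyond the scatter). Compound 3 is therefore estimated at 20 nM, in the range 5 nM to 100 nM.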

Compound 3, half-maximal inhibitory concentration: 6.6 nM
For compound 3 the middle estimate is 3.0-fold (0.48 log units) above the measured one, within the range that was stated.
By their numbers in this assay, from the lowest: compounds 3 and 1 (each within the scatter of the next); then compound 2.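

In this assay, the change from 3-(methylcarbamoyl)phenyl to 4-(trifluoromethoxy)phenyl on the sulfonyl sulfur gives a 36-fold lower number from compound 2 to compound 3 (1.56 log units; beyond the scatter) and so shows that the high number of compound 2 does not extend to every replacement of the 3-methoxyphenyl group of compound 1. The change from 3-methoxyphenyl to 4-(trifluoromethoxy)phenyl gives a 1.8-fold lower number from compound 1 to compound 3 (0.26 log units; within the scatter) and so leaves these two groups indistinguishable on this read-out, although they differ in both the substituent and its printed ring position. No measurement offered here explains either step.

Going by these compounds, whether the large step belongs to the methylcarbamoyl group itself or to its ring position remains open. On these data alone, it is also open whether an amine or a carboxylic acid on this aryl ring would give a number close to those of compound 1 and compound 3 or close to that of compound 2.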